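This account rests on a few compounds, and the source may have more. Where it says the series, first, only, none or still open, it means among the compounds named here.

Compound 2, `CNC(=O)c1cc(C(=O)NC2CC2)cn(Cc2cccc([C@@H](C)O)c2)c1=O`, stands only at a limit in a physicochemical assay for solubility; on this read-out higher numbers stand for higher solubility and lower numbers for lower solubility. In this assay compound 2 gives >= 131 ug/mL, which is a limit of the assay and not a number. Within the data shown here, its one measured neighbour, compound 1, `CNC(=O)c1cc(C(=O)NC2CC2)cn(Cc2ccc(F)cc2)c1=O`, also reaches only a limit. In this assay compound 1 gives >= 162 ug/mL, again a limit rather than a number. The step that the two limits leave unreadable from compound 1 to compound 2 therefore cannot be read, since the limit of >= 131 ug/mL in this assay, at which 1 of the 2 values shown sits, and the limit of >= 162 ug/mL in this assay, at which 1 of the 2 values shown sits, both sit at limits. The unmeasured compound 3, `CNC(=O)c1cc(C(=O)NC2CC2)cn(Cc2cccc3cn[nH]c23)c1=O`, differs from compound 2 by 1H-indazol-7-yl in place of 3-(1-hydroxyethyl)phenyl on a saturated chain carbon bound to an aromatic nitrogen. No readable measured step bears on this change, so no direction beyond the scatter can be drawn from the numbers shown. Compound 3 is estimated in this assay at 100 ug/mL, within a range from 30 ug/mL to 200 ug/mL. The step of an at least 1.3-fold lower number from compound 2 to compound 3 (0.11 log units; that floor lies within the scatter) is expected to be modest, with a fair chance that the assay again reports only a limit.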

Compound 3, solubility: >= 181 ug/mL
Compound 3: no number, only a limit; the forecaster's own chance of this, stated with the estimate: 40%; middle value at least 1.8-fold (0.25 log units) from the limit.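

In this assay compound 3 also reaches only a limit, so its steps from compound 1 and compound 2 cannot be read. The compounds shown leave open where the true solubilities of compound 1, compound 2 and compound 3 lie, and whether they differ at all.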